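The source may hold more compounds than are shown below. What is called first, only, known or untested is meant among the compounds shown, and "the series" means these compounds.

Measured in a functional assay on CHO cells with adenosine receptor A1 (Homo sapiens) as the target, read by cAMP accumulation and immunoassay, with a stated time of 6 min, tested at 10 uM; a lower number here means a stronger effect, a higher number a weaker effect of the compound at the concentration tested:
compound 1, `Nc1scc(CN2CCN(c3cccc(Cl)c3Cl)CC2)c1C(=O)c1ccc(Cl)cc1`, gives -77%
compound 2, `Nc1scc(CN2CCN(c3cccc(C(F)(F)F)c3)CC2)c1C(=O)c1ccc(Cl)cc1`, gives -80%
compound 3, `Nc1scc(CN2CCN(c3ccc(OC(F)(F)F)cc3)CC2)c1C(=O)c1ccc(Cl)cc1`, gives -74%

Compound 3 carries the highest of the three numbers, but its distance from the others is small: the step of a number 3 percentage points higher from compound 1 to compound 3 (within the scatter) and the step of a number 6 percentage points higher from compound 2 to compound 3 (within the scatter) both stay within the usual scatter, so no order among compounds 1, 2 and 3 can be read from these values. Compound 4, `Nc1scc(CN2CCN(c3ccc(F)cc3F)CC2)c1C(=O)c1ccc(Cl)cc1`, has not yet been measured in this assay. Its difference from compound 3 is 2,4-difluorophenyl in place of 4-(trifluoromethoxy)phenyl on an amine nitrogen in a ring. Among the compounds with values here, every measured step so far is of the same kind, an exchange of the aryl group on the amine nitrogen in the ring: a number 3 percentage points lower from compound 1 to compound 2 (within the scatter), a number 3 percentage points higher from compound 1 to compound 3 (within the scatter) and a number 6 percentage points higher from compound 2 to compound 3 (within the scatter), none of them beyond the scatter. On that basis compound 4 is expected to show no step beyond the scatter, a number 1 percentage points lower from compound 3 to compound 4 (within the scatter). Compound 4 is therefore estimated at -75% in this assay, with a range from -87% to -62%.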

Compound 4, a percentage reported as activity, at one concentration (the size of the read-out at that concentration, not a potency): -82%
Compound 4: the middle estimate sits 7 percentage points above what was measured; the range from low to high includes it.
By their numbers in this assay, from the lowest: compounds 4, 2, 1 and 3 (each within the scatter of the next).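

In this assay, the exchange for 2,4-difluorophenyl on the amine nitrogen in the ring gives a number 8 percentage points lower from compound 3 to compound 4 (within the scatter), a number 2 percentage points lower from compound 2 to compound 4 (within the scatter) and a number 5 percentage points lower from compound 1 to compound 4 (within the scatter). This position therefore takes a fourth aryl group without a step beyond the scatter, and the change from 4-(trifluoromethoxy)phenyl also shows that going from 11 heavy atoms to 8, and from 1 hydrogen-bond acceptor to 0, moves the number no further than that. No evidence is at hand that would explain how close these values lie.

The compounds shown all carry a halogen-containing phenyl group here, so it remains open whether an unsubstituted phenyl, a pyridine ring, or a phenyl bearing an amine or a carboxylic acid would stay in the same range. The read-out comes from a single concentration, so any differences in potency among these compounds also remain open.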